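The compounds below may be only part of what the source reports. "The series", "measured", "known", "first", "only" and "open" are said of these compounds alone.

Measured compounds in a functional assay on UACC-257 cells (Homo sapiens) for cytotoxicity, read by sulforhodamine B assay, with a stated time of 48 h; on this read-out lower numbers stand for stronger inhibition of growth and higher numbers for weaker inhibition of growth:
compound 1, `ClCc1ccc(Cn2cnc3c(Cl)ncnc32)cc1`, gives 7410 nM;
compound 2, `ClCc1ccccc1Cn1cnc2c(Cl)nc(Cl)nc21`, gives 1820 nM.

Compound 2 stands lowest of the two numbers in this assay; its nearest neighbour is compound 1, whose number is higher by a gap beyond the scatter. Among the measured compounds shown here, the two share the core but differ both in the count of chloro groups on the core and in where the chloromethyl sits on the benzyl ring, so no single step links them.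

Compound 3, `ClCc1ccccc1Cn1cnc2c(Cl)ncnc21`, is not yet measured. It differs from compound 2 in one place: hydrogen in place of chloro on an aromatic carbon, the position between two ring nitrogen atoms.

No step of this kind is shown among the measured compounds. Compound 1, which also carries a single chloro on the core, gives 7410 nM, a weaker number than compound 2, but its benzyl ring also differs, so it cannot fix the size of the step. The expectation for compound 3 is a moderate rise in the number, an estimated 2.2-fold higher number from compound 2 to compound 3 (0.34 log units; beyond the scatter). Compound 3 is therefore expected at about 4000 nM, within 1500 nM to 12000 nM.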

Compound 3, concentration for 50% growth inhibition: 10700 nM
Estimate against measurement, compound 3: 2.7-fold (0.43 log units) below; low and high end bracket the measured number.
By their numbers in this assay, from the lowest: compound 2; then compounds 1 and 3 (each within the scatter of the next).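

Working notes on the series: in this assay the position between two ring nitrogen atoms can now be read on its own, with the benzyl ring held constant, and the change to hydrogen in place of chloro gives a 5.9-fold higher number from compound 2 to compound 3 (0.77 log units; beyond the scatter) as a step. The stronger growth inhibition of compound 2 therefore goes with the chloro group at this position, which the earlier comparison could not show because two places differed. With a single chloro on the core, compound 3 gives 10700 nM and compound 1 gives 7410 nM in this series, and these two numbers lie within the scatter of each other, so where the chloromethyl sits on the benzyl ring has no readable effect in this pair. No measurement bears on the reason for the step.

Still open, going by these compounds, is whether the step is particular to chloro, since an amine or a methoxy group at this position would separate that question from the mere presence of a substituent. On these data alone, it is also open whether the step holds with the chloromethyl placed as in compound 1, and whether it survives replacing chloromethyl with a hydroxymethyl or a plain methyl group.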